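Testing a Branched Chain in Place of Cyclopentyl

The source may hold more compounds than are shown below. What is called first, only, known or untested is meant among the compounds shown, and "the series" means these compounds.

The measured compounds:
compound 1, `O=C(O)/C(=N/OC(c1ccc(OCc2ccc3ccccc3n2)cc1)C1CCCCC1)c1ccccc1`, giving 31 nM in a functional assay for inhibition of Polyunsaturated fatty acid 5-lipoxygenase (Homo sapiens); on this read-out higher numbers stand for weaker inhibition and lower numbers for stronger inhibition
compound 2, `O=C(O)C1CCC(=NOC(c2ccc(OCc3ccc4ccccc4n3)cc2)C2CCCCC2)CC1`, giving 67 nM
compound 3, `C/C(=N\OC(c1ccc(OCc2ccc3ccccc3n2)cc1)C1CCCC1)C(=O)O`, giving 16 nM

On the numbers shown, compound 3 is separated from compound 1 by less than the usual scatter and from compound 2 by more than it, so only the gap to compound 2 can be read as a real difference. Compound 4, `C/C(=N\OC(CC(C)(C)c1ccccc1)c1ccc(OCc2ccc3ccccc3n2)cc1)C(=O)O`, carries the change (2-methyl-2-phenylpropyl in place of cyclopentyl on a saturated chain carbon bound to an aromatic carbon and an oxygen). For the measured compounds named here, the single step measured so far, a 2.2-fold higher number from compound 1 to compound 2 (0.33 log units; beyond the scatter), concerns a different part of the molecule, on an oxygen on a saturated carbon, and does not touch the position altered here. Going by the values given here, compound 1 and compound 3 differ at two places at once, so their pair yields no isolated step; their values simply sit within the scatter of each other. Among the compounds with values here, there is thus no measured step that bears on the replacement of cyclopentyl by 2-methyl-2-phenylpropyl, and no direction can be drawn from the data. Compound 4 is therefore expected to give about 25 nM in this assay, with a range from 8 nM to 80 nM. This estimate means a step of a 1.6-fold higher number from compound 3 to compound 4 (0.19 log units; within the scatter), which is expected to remain close to the scatter rather than clearly beyond it.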

Compound 4, half-maximal inhibitory concentration: 22 nM
Compound 4: the middle estimate sits 1.1-fold (0.06 log units) above what was measured, and the stated range covers the measured number.
By their numbers in this assay, from the lowest: compounds 3, 4 and 1 (each within the scatter of the next); then compound 2.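

In this assay, for the compounds shown here, the first step at this position, a 1.4-fold higher number from compound 3 to compound 4 (0.14 log units; within the scatter), does not separate 2-methyl-2-phenylpropyl from cyclopentyl on a saturated chain carbon bound to an aromatic carbon and an oxygen. Within this one pair, the group can change from one with a five-membered non-aromatic ring of carbon only to one with a six-membered aromatic ring of carbon only, and the read-out stays within the usual scatter. Nothing available here bears on why the two groups read alike.

The compounds shown leave open whether the phenyl ring of 2-methyl-2-phenylpropyl matters at this place, which a plain 2,2-dimethylpropyl chain could test, and whether a group carrying an amine or a hydroxyl would also stay within the scatter of compound 3. Going by these compounds alone, they also leave open whether the same exchange would give a similarly small step on the parts that carry the carboxylic acid in compound 1 and compound 2, since the only step at this position comes from the pair sharing the part found in compound 3.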